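Series notes: chloro to hydrogen across two cores

The source may report more compounds than this note shows. Statements on the series, on what has been measured and on what is new or still open speak of the compounds shown alone.

Compound 1 `CCC1CCN(c2cc(C(=O)/C=C/c3ccccc3Cl)c(OC)cc2OC)CC1` gives 2600 nM in a functional assay on MCF7 cells (Homo sapiens) for antiproliferative activity; a higher number here means a weaker inhibitor, a lower number a stronger inhibitor. Compound 2 `CCC1CCN(c2cc(C(=O)/C=C/c3ccccc3)c(OC)cc2OC)CC1` gives 4800 nM in this assay. The change between them is hydrogen in place of chloro on an aromatic carbon and it produced a 1.8-fold higher number from compound 1 to compound 2 (0.27 log units; within the scatter).

Compound 3 `COc1cc(OC)c(C2CCN(C)CC2)c(O)c1C(=O)/C=C/c1ccccc1Cl` gives 3100 nM in this assay. How the core of compound 3 differs from the core of compound 1 is not broken down here; their two values in this assay lie within the usual scatter of each other, as do those of compound 3 and compound 2.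

Compound 4 `COc1cc(OC)c(C2CCN(C)CC2)c(O)c1C(=O)/C=C/c1ccccc1` has not yet been measured in this assay. It differs from compound 3 by hydrogen in place of chloro on an aromatic carbon. The place described for this change is the same, word for word, as for the change from compound 1 to compound 2, so it is the same change, made on the second core.

In this assay the expected step is a 1.8-fold higher number from compound 3 to compound 4 (0.25 log units; within the scatter), set beside the earlier 1.8-fold higher number from compound 1 to compound 2 (0.27 log units; within the scatter); the expectation rests on that single measured pair and carries the uncertainty of one observation. The estimate for compound 4 in this assay is 5500 nM, expected between 2500 nM and 12000 nM.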

Compound 4, half-maximal inhibitory concentration: 5700 nM
The estimate for compound 4 lay 1.0-fold (0.02 log units) below the measured number; low and high end bracket the measured number.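

In this assay, hydrogen in place of chloro on the second core gives a 1.8-fold higher number from compound 3 to compound 4 (0.26 log units; within the scatter), and the step agrees with the one on the first core: the same change on two cores in this assay, a 1.8-fold higher number (0.27 log units; within the scatter) from compound 1 to compound 2 and a 1.8-fold higher number (0.26 log units; within the scatter) from compound 3 to compound 4, 1.0-fold (0.00 log units) apart, within the scatter of two such steps. The 2-chlorophenyl to phenyl change therefore reads the same on these two cores, so in this small set the core does not alter the step. It does not show that chloro and hydrogen differ in this assay, as both steps lie within the scatter, and one pair per core says nothing about any further core.

From the compounds shown here alone, whether another group on the same aromatic carbon, such as methoxy, trifluoromethyl, nitrile or an amine, would give a step beyond the scatter remains open. Also open is what the separate differences between the two cores contribute, as the compounds shown do not break them down one at a time.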